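Swapping the benzyl for a pyridylmethyl ether

A few compounds are considered here, and "the series" means these few. Any claim that something is new, unique, unknown or untested is made for them only; others in the source may bear on it.

Compounds measured so far, each with its value in an assay on CHO cells for antagonist activity at transient receptor potential cation channel subfamily V member 1 (Homo sapiens), read by FLIPR; a lower number here means a stronger inhibitor, a higher number a weaker inhibitor:
- compound 1, `CC(C)COc1nc(C(F)(F)Cl)ccc1CNC(=O)C(C)c1ccc(NS(C)(=O)=O)c(F)c1`: 0.6 nM
- compound 2, `CC(C(=O)NCc1ccc(C(F)(F)Cl)nc1OC1CCCCC1)c1ccc(NS(C)(=O)=O)c(F)c1`: 0.9 nM
- compound 3, `CC(C(=O)NCc1ccc(C(F)(F)Cl)nc1OCc1ccccc1)c1ccc(NS(C)(=O)=O)c(F)c1`: 0.9 nM

All three share a core and differ only in the group on the ether oxygen of the aromatic ring. Compound 3 stands level with compound 2 at the digits shown, and the two together carry the highest numbers of the three; the remaining gap is a 1.5-fold higher number from compound 1 to compound 3 (0.18 log units; within the scatter), which lies within the scatter. So far nothing at this position has moved the number beyond the scatter: a 1.5-fold higher number from compound 1 to compound 2 (0.18 log units; within the scatter) and no change at the digits printed from compound 2 to compound 3 (within the scatter) are both small.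

Compound 4, `CC(C(=O)NCc1ccc(C(F)(F)Cl)nc1OCc1cccnc1)c1ccc(NS(C)(=O)=O)c(F)c1`, has not yet been measured. It differs from compound 3 in one place: pyridin-3-yl in place of phenyl on a saturated chain carbon bound to an oxygen on an aromatic ring. The change is a single atom swap within an aromatic ring that keeps its size. Within the data shown here, the steps that bear on it, no change at the digits printed from compound 2 to compound 3 (within the scatter) and a 1.5-fold higher number from compound 1 to compound 3 (0.18 log units; within the scatter), show this position tolerating shapes from isobutyl to benzyl without a step beyond the scatter. A change no larger than those is therefore expected to give a step of a 1.3-fold higher number from compound 3 to compound 4 (0.12 log units; within the scatter), essentially none beyond the scatter. Compound 4 is estimated to come in at 1.2 nM, with a range from 0.4 nM to 4 nM.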

Compound 4, inhibition constant: 14.6 nM
Compound 4: middle estimate off by 12-fold (1.09 log units), on the low side; the whole stated range lies below it.
By their numbers in this assay, from the lowest: compounds 1, 2 and 3 (each within the scatter of the next); then compound 4.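

In this assay, this position proves less forgiving than the isobutyl, cyclohexyl and benzyl ethers suggested: replacing one ring carbon with nitrogen, with the ring size and heavy-atom count unchanged, gives a large step (a 16-fold higher number from compound 3 to compound 4 (1.21 log units; beyond the scatter)). Among these compounds, the steps from the other two ethers are just as large (a 16-fold higher number from compound 2 to compound 4 (1.21 log units; beyond the scatter); a 24-fold higher number from compound 1 to compound 4 (1.39 log units; beyond the scatter)), so compound 4 stands apart from all three, and the tolerance seen earlier covers only groups built from carbon and hydrogen, since pyridin-3-yl is the only group here with a hetero atom in its ring. The data shown include no measurement that would explain this loss of potency.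

With a single nitrogen-containing group at this position, the compounds shown leave open whether the loss is specific to pyridin-3-yl or would also appear with other groups that carry nitrogen or oxygen. They also leave open how an amine or a carboxylic acid on a saturated chain at this oxygen would behave, and whether a longer chain between the oxygen and the pyridin-3-yl would bring the number back down.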